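Thiophen-3-yl in Place of Phenyl: Expectation for Compound 3

The source may report more compounds than this note shows. Statements on the series, on what has been measured and on what is new or still open speak of the compounds shown alone.

Measured in an assay on isolated protein for inhibition of DNA topoisomerase 1 (Homo sapiens), with a stated time of 30 min, tested at 100 uM; a higher number here means a stronger effect of the compound at the concentration tested, a lower number a weaker effect:
compound 1, `Oc1ccc(-c2cc(-c3ccccc3)nc(-c3ccccc3Cl)c2)cc1`: 13.6%
compound 2, `Oc1cccc(-c2cc(-c3ccc(Cl)cc3)nc(-c3cccnc3)c2)c1`: 2.8%

Of the compounds shown here, two have been measured. Going by the values given here, compound 1 gives the higher of the two numbers in this assay; the only neighbour, compound 2, lies lower by a gap that is beyond the usual scatter. Among the compounds with values here, both share a core with a 2-chlorophenyl group or a pyridyl group and a hydroxyphenyl group around a ring nitrogen, but no pair of them differs in a single place, so the two values show only that compound 1 is the stronger of the two at the tested concentration and nothing about the worth of any single change.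

Compound 3, `Oc1ccc(-c2cc(-c3ccsc3)nc(-c3ccccc3Cl)c2)cc1`, has not been measured. It differs from compound 1 in one place: thiophen-3-yl in place of phenyl on an aromatic carbon. The hydroxyphenyl and 2-chlorophenyl groups of compound 1 stay as they are.

Within the data shown here, no measured step speaks to this exchange. The account therefore expects for compound 3 a step from compound 1 of about a number 1.6 percentage points lower from compound 1 to compound 3 (within the scatter), which is no change beyond the scatter. For compound 3 in this assay the estimate is 12%, expected to fall between 2% and 25%.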

Compound 3, a percentage reported as inhibition, at one concentration (the size of the read-out at that concentration, not a potency): 4.1%
The estimate for compound 3 lay 7.9 percentage points above the measured number; the measured number falls inside the stated range.
By their numbers in this assay, from the lowest: compounds 2, 3 and 1 (each within the scatter of the next, the first and the last beyond it).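

With phenyl exchanged for thiophen-3-yl on the aromatic carbon next to the ring nitrogen, the account has its first comparison of compounds that differ in one place: in this assay the exchange gives a number 9.5 percentage points lower from compound 1 to compound 3 (within the scatter), so this pair cannot be told apart at the tested concentration. This replacement of a six-membered carbon ring by a five-membered ring with one sulfur atom, with the 2-chlorophenyl and 4-hydroxyphenyl groups held the same, therefore produces no change beyond the usual scatter at this position, although one pair cannot establish a general rule for it. No measurement at hand offers an explanation for this result.

The compounds shown leave open how an amine, a carboxylic acid or a longer chain on this same aromatic carbon would read in this assay, since phenyl and thiophen-3-yl are the only groups compared there. They also leave open whether the same exchange would give a similar step when the 2-chlorophenyl or 4-hydroxyphenyl group is replaced by another group.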